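A few compounds are considered here, and "the series" means these few. Any claim that something is new, unique, unknown or untested is made for them only; others in the source may bear on it.

Of the compounds shown here, three sharing one core have been read so far, and none gives a number. Compound 1 `Nc1nc(NCCNc2ncc(-c3ncc[nH]3)c(-c3ccccc3Br)n2)ccc1[N+](=O)[O-]`, which carries a 2-bromophenyl group, gives > 0.5 h in an ADME assay on microsomes from liver (Canis lupus familiaris) for metabolic stability (on this read-out higher numbers stand for a longer-lived compound and lower numbers for a shorter-lived compound), and that is a limit of the assay. Compound 2 `Nc1nc(NCCNc2ncc(-c3ncc[nH]3)c(-c3ccc(F)cc3F)n2)ccc1[N+](=O)[O-]`, with a 2,4-difluorophenyl group, gives > 0.5 h which is again a limit. Compound 3 `Nc1nc(NCCNc2ncc(-c3ncc[nH]3)c(-c3ccc(Cl)cc3F)n2)ccc1[N+](=O)[O-]`, with a 4-chloro-2-fluorophenyl group, gives > 0.5 h and this too is only a limit. All the data therefore stand at the limit of > 0.5 h in this assay, at which 3 of the 3 values shown sit, and compound 3 has no place above or below the others.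

Compound 4 `COc1cc(Cl)ccc1-c1nc(NCCNc2ccc([N+](=O)[O-])c(N)n2)ncc1-c1ncc[nH]1` differs from compound 3 by one change methoxy in place of fluoro on an aromatic carbon that takes 4-chloro-2-fluorophenyl to 4-chloro-2-methoxyphenyl. Going by the values given here, three measured steps bear on this only loosely: a step that the two limits leave unreadable from compound 1 to compound 2 and a step that the two limits leave unreadable from compound 1 to compound 3 and also a step that the two limits leave unreadable from compound 2 to compound 3 for chloro in place of fluoro. None of them has a readable size, and none brings in methoxy. No step beyond the scatter can therefore be expected in this assay in either direction. The estimate accordingly means a step that the limit leaves unreadable from compound 3 to compound 4 as the expected step. For compound 4 the estimate is 0.6 h with 0.3 h to 1.2 h as the expected range.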

Compound 4, half-life: > 0.5 h
Compound 4 gave a limit, no number (the forecaster's own chance of this, stated with the estimate: 70%); the middle value does not contradict the limit.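

In this assay compound 4 gives > 0.5 h as a limit, not a number. Going by these compounds alone, no step from compound 1, compound 2 or compound 3 to compound 4 can be read, since all four compounds stand at one limit: the limit of > 0.5 h in this assay, at which 4 of the 4 values shown sit. The compounds shown leave open whether the 2-bromophenyl, 2,4-difluorophenyl, 4-chloro-2-fluorophenyl and 4-chloro-2-methoxyphenyl groups differ at all in this assay and, if they do, by how much.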